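Swapping the aryl group on a pyrazole acid series

A few compounds are considered here, and "the series" means these few. Any claim that something is new, unique, unknown or untested is made for them only; others in the source may bear on it.

Compound 1 `COc1cc(-c2c(C)nn(-c3nc(-c4ccc(Cl)c(Cl)c4)c(SC(C)C)s3)c2C(=O)O)cc(C(F)(F)F)c1` is measured in a functional assay on BJAB cells (Homo sapiens) for antiproliferative activity, with a stated time of 4 days (a higher number here means that more compound is needed for the effect, a lower number that less compound is needed), at 1380 nM, the lowest of the three numbers recorded. Compound 2 `Cc1nn(-c2nc(-c3ccc(Cl)c(Cl)c3)c(SC(C)C)s2)c(C(=O)O)c1-c1ccccc1[N+](=O)[O-]` gives 4700 nM in this assay, and compound 3 `Cc1nn(-c2nc(-c3ccc(Cl)c(Cl)c3)c(SC(C)C)s2)c(C(=O)O)c1-c1cnccn1` gives 14000 nM. Both known steps change the same aryl group: a 3.4-fold higher number from compound 1 to compound 2 (0.53 log units; beyond the scatter), and a 10-fold higher number from compound 1 to compound 3 (1.01 log units; beyond the scatter). Compound 4 `Cc1cccc(-c2c(C)nn(-c3nc(-c4ccc(Cl)c(Cl)c4)c(SC(C)C)s3)c2C(=O)O)c1` carries the change (3-methylphenyl in place of 3-methoxy-5-(trifluoromethyl)phenyl on an aromatic carbon). Because a 3.4-fold higher number from compound 1 to compound 2 (0.53 log units; beyond the scatter) and a 10-fold higher number from compound 1 to compound 3 (1.01 log units; beyond the scatter) both raised the number, a rise is expected here too, though the entering group is again an all-carbon ring, so a smaller rise than either is anticipated. The step is expected to be a 2.2-fold higher number from compound 1 to compound 4 (0.34 log units; beyond the scatter). Compound 4 is therefore estimated at 3000 nM in this assay, within 1200 nM to 8000 nM.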

Compound 4, half-maximal effective concentration: 17000 nM
Compound 4: middle estimate off by 5.7-fold (0.75 log units), on the low side; the measured number lies above the stated range.
By their numbers in this assay, from the lowest: compound 1; then compound 2; then compounds 3 and 4 (each within the scatter of the next).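

Compound 4 shows that a ring of carbon only at this position does not keep the number low in this assay (a 12-fold higher number from compound 1 to compound 4 (1.09 log units; beyond the scatter)). Its number stands level with that of the pyrazin-2-yl compound (a 1.2-fold higher number from compound 3 to compound 4 (0.08 log units; within the scatter)) and apart from that of the 2-nitrophenyl compound (a 3.6-fold higher number from compound 2 to compound 4 (0.56 log units; beyond the scatter)), so among these compounds the number does not follow whether the entering ring holds nitrogen. Nothing available explains this step. From the compounds shown here alone, it remains open whether the methoxy or the trifluoromethyl group alone would keep the lower number, and what an amine or a longer chain on this ring would give.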